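A few compounds are considered here, and "the series" means these few. Any claim that something is new, unique, unknown or untested is made for them only; others in the source may bear on it.

Of the compounds shown here, three sharing one core have been tested so far. Compound 1 `CC(C)(C)c1cc(-c2cc(=O)c3ccc(OCC(=O)N4CCN(Cc5ccccc5)CC4)cc3o2)cc(C(C)(C)C)c1O` gives 3000 nM in a functional assay for inhibition; on this read-out higher numbers stand for weaker inhibition and lower numbers for stronger inhibition; compound 2 `CCOC(=O)CCCCOc1ccc2c(=O)cc(-c3cc(C(C)(C)C)c(O)c(C(C)(C)C)c3)oc2c1` gives 3000 nM; and compound 3 `CN(C)CCCOc1ccc2c(=O)cc(-c3cc(C(C)(C)C)c(O)c(C(C)(C)C)c3)oc2c1` gives 700 nM, the lowest of the three numbers. Going by the values given here, the one single-point step measured, a 4.3-fold lower number from compound 2 to compound 3 (0.63 log units; beyond the scatter), shows that bringing in the dimethylamino group went with a clearly lower number. Compound 4 `COc1ccc2c(=O)cc(-c3cc(C(C)(C)C)c(O)c(C(C)(C)C)c3)oc2c1` removes that group altogether: hydrogen in place of 2-(dimethylamino)ethyl on a saturated chain carbon bound to an oxygen on an aromatic ring. Among the compounds with values here, no measured step covers exactly this loss, but the step from compound 2 to compound 3 suggests that the dimethylamino group is linked to the lower number, so taking it away is expected to raise the number by a modest step, a 3.6-fold higher number from compound 3 to compound 4 (0.55 log units; beyond the scatter). Compound 4 is therefore estimated at 2500 nM, with a likely range from 900 nM to 7000 nM.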

Compound 4, half-maximal inhibitory concentration: 1000 nM
Beside the measured number, compound 4's estimate is 2.5-fold (0.40 log units) above it; the measured number falls inside the stated range.
By their numbers in this assay, from the lowest: compounds 3 and 4 (each within the scatter of the next); then compounds 1 and 2 (each within the scatter of the next).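

In this assay, cutting 3-(dimethylamino)propoxy back to methoxy gives a 1.4-fold higher number from compound 3 to compound 4 (0.15 log units; within the scatter), so the dimethylamino chain is not needed for the lower number. The other comparison, a 3.0-fold lower number from compound 2 to compound 4 (0.48 log units; beyond the scatter), suggests that the earlier gap between compound 2 and compound 3 reflects the ester chain going with a higher number, rather than the amine going with a lower one. No measurement here offers an explanation for either step.

The compounds shown leave open what a carboxylic acid on the chain, as a 3-carboxypropyl group in place of methyl, would do. They also leave open the effect of a bare hydrogen in place of that methyl.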